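A few compounds are considered here, and "the series" means these few. Any claim that something is new, unique, unknown or untested is made for them only; others in the source may bear on it.

Compound 1 `CCCOC(=O)C1=C(C)NC(=O)NC1c1ccsc1`: 44%
Compound 2 `CC1=C(C(=O)C2CC2)C(c2ccsc2)NC(=O)N1`: 2%
Compound 3 `CCSC(=O)C1=C(C)NC(=O)NC1c1ccco1`: 6%

These three compounds were tested in an assay on membranes from CHO cells for displacement of a labelled ligand from adenosine receptor A1 (Homo sapiens), read by scintillation counting, with a stated time of 60 min, tested at 1 uM; on this read-out higher numbers stand for more inhibition at the one concentration tested (going by the name of the read-out) and lower numbers for less inhibition. Compound 3 stands second highest of the three: its number sits within the scatter of compound 2 and well below that of compound 1. Compound 4 `CCSC(=O)C1=C(C)NC(=O)NC1c1ccsc1` has not yet been measured. It differs from compound 3 by thiophen-3-yl in place of furan-2-yl on a saturated ring carbon. Among the measured compounds shown here, the only measured step, a number 42 percentage points lower from compound 1 to compound 2 (beyond the scatter), concerns the group on the carbonyl carbon rather than the ring on the saturated ring carbon, so no measured step speaks to this ring swap. Without such a guide, the step of a number 6 percentage points higher from compound 3 to compound 4 (within the scatter) is expected to stay within the scatter. Compound 4 is therefore estimated at 12%, in a range from -5% to 35%.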

Compound 4, a percentage reported as inhibition, at one concentration (the size of the read-out at that concentration, not a potency): 11%
Beside the measured number, compound 4's estimate is 1 percentage points above it, and the stated range covers the measured number.
By their numbers in this assay, from the lowest: compounds 2, 3 and 4 (each within the scatter of the next); then compound 1.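

Thiophen-3-yl in place of furan-2-yl on the saturated ring carbon gives a number 5 percentage points higher from compound 3 to compound 4 (within the scatter) and so, with the ethylsulfanyl carbonyl group present, these two rings cannot be told apart. With thiophen-3-yl held fixed, ethylsulfanyl in place of cyclopropyl gives a number 9 percentage points higher from compound 2 to compound 4 (within the scatter) while ethylsulfanyl in place of propoxy gives a number 33 percentage points lower from compound 1 to compound 4 (beyond the scatter) and so, of these three carbonyl groups, only propoxy stands apart. No measured evidence here explains these results. Still open, from the compounds shown here alone, is whether an amine on the saturated ring carbon, or a longer chain such as butoxy on the carbonyl carbon, would change the number.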